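The source may report more compounds than this note shows. Statements on the series, on what has been measured and on what is new or still open speak of the compounds shown alone.

Compounds measured so far in an assay on SH-EP1 cells for agonist activity at Neuronal acetylcholine receptor; alpha4/beta2 (Homo sapiens), read by FLIPR and calcium flux; a higher number here means that more compound is needed for the effect, a lower number that less compound is needed:
compound 1 `O=C(C1CCC1)N1CC2CC(C1)N2`, 2900 nM;
compound 2 `O=C(C1CC=CC1)N1CC2CC(C1)N2`, 6600 nM;
compound 3 `O=C(CC1C=CCC1)N1CC2CC(C1)N2`, 14000 nM.

Compound 1 has the lowest number of the three, with compound 2 giving a higher number beyond the scatter and compound 3 higher still. Compound 4 `C[C@H]1C[C@H]1C(=O)N1CC2CC(C1)N2` differs from compound 1 by 2-methylcyclopropyl in place of cyclobutyl on a carbonyl carbon. Among the compounds with values here, both groups hold the same number of carbons, and no measured pair in this assay shows what such a ring change does. The step from compound 1 to compound 4 is therefore expected to be small, a 1.2-fold higher number from compound 1 to compound 4 (0.08 log units; within the scatter), with no clear direction beyond the scatter. For compound 4 the estimated value in this assay is 3500 nM, within a range from 1200 nM to 10000 nM.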

Compound 4, half-maximal effective concentration: 2200 nM
Beside the measured number, compound 4's estimate is 1.6-fold (0.20 log units) above it, within the range that was stated.
By their numbers in this assay, from the lowest: compounds 4 and 1 (each within the scatter of the next); then compound 2; then compound 3.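

In this assay, within the data shown here, this is the first pair among the compounds that differs in one place, and it gives a 1.3-fold lower number from compound 1 to compound 4 (0.12 log units; within the scatter). On a carbonyl carbon whose other neighbours are an amide-type nitrogen in a ring, 2-methylcyclopropyl and cyclobutyl therefore cannot be told apart in this read-out. Nothing measured explains this result.

The compounds shown leave open what the other stereoisomers of 2-methylcyclopropyl would give. They also leave open whether a group carrying an amine or a carboxylic acid would be accepted at this place.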